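Swapping Phenyl for a Sulfamoylthiophene in a Cytotoxicity Series

The source may hold more compounds than are shown below. What is called first, only, known or untested is meant among the compounds shown, and "the series" means these compounds.

Of the compounds shown here, two that share one core have been measured so far. Compound 1 `CS(=O)(=O)c1ccc(Cc2nnc3n2N=C(c2ccccc2)CS3)cc1` gives 25000 nM in a functional assay on RAW264.7 cells (Mus musculus) for cytotoxicity, read by MTT assay, with a stated time of 48 h; a higher number here means a weaker inhibitor, a lower number a stronger inhibitor. Compound 2 `CS(=O)(=O)c1ccc(Cc2nnc3n2N=C(c2ccc(-c4ccccc4)cc2)CS3)cc1`, which carries phenyl in place of hydrogen on an aromatic carbon, gives 12500 nM in this assay. Among the measured compounds shown here, the move a 2.0-fold lower number from compound 1 to compound 2 (0.30 log units; within the scatter) is the only step between measured compounds, and it stays within the scatter. On the two numbers in hand, compound 1 stands highest, and its nearest neighbour, compound 2, lies within the scatter of it.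

The unmeasured compound 3 `CS(=O)(=O)c1ccc(Cc2nnc3n2N=C(c2cc(Cl)sc2S(N)(=O)=O)CS3)cc1` differs from compound 1 in a single place: 5-chloro-2-sulfamoylthiophen-3-yl in place of phenyl on a carbon with a double bond to nitrogen. For the measured compounds named here, no measured step touches this substituent on the carbon with a double bond to nitrogen, and the one step that exists, from compound 1 to compound 2, was itself within the scatter. The measured pair therefore offers no ground for expecting a shift beyond the scatter in this assay in either direction. Compound 3 is estimated at 25000 nM, within a range from 8000 nM to 70000 nM, which amounts to an expected step of no change at the digits printed from compound 1 to compound 3 (within the scatter).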

Compound 3, half-maximal inhibitory concentration: > 100000 nM
Compound 3 was reported as a limit (the forecaster's own chance of this, stated with the estimate: 15%); middle value at least 4.0-fold (0.60 log units) from the limit.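

Among the compounds shown here, the carbon with a double bond to nitrogen is the first place where a change moves the number beyond the scatter in this assay: 5-chloro-2-sulfamoylthiophen-3-yl in place of phenyl gives an at least 4.0-fold higher number from compound 1 to compound 3 (0.60 log units; beyond the scatter), and the direction is towards a weaker inhibitor. For the compounds shown here, the only earlier step, a 2.0-fold lower number from compound 1 to compound 2 (0.30 log units; within the scatter), touched a different part of the molecule and left the two compounds indistinguishable, so the series now holds one change that separates compounds and one that does not. Compound 3 gives a limit of the assay and not a number, so the step has a floor but no measured size: the limit of > 100000 nM in this assay, at which 1 of the 3 values shown sits.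

The entering group differs from phenyl in several ways at once, bringing a five-membered ring with a hetero atom, a chlorine and a sulfamoyl group together, and the compounds shown do not tell which of these parts accounts for the step. On these data alone, it remains open how a plain thiophene ring, or a phenyl ring carrying only a chlorine, an amine or a carboxylic acid, would read at this carbon.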